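Methylating the triazole nitrogen of the weakest analogue

The source may hold more compounds than are shown below. What is called first, only, known or untested is meant among the compounds shown, and "the series" means these compounds.

Three compounds share one core and differ only in the side chain on one aromatic carbon. Compound 1 `CC(C)Cn1c(=O)n(C)c(=O)c2nc(SCCCCO)c(Cc3cccc4ccccc34)nc21` gives 37 nM in a functional assay on Raji cells (Homo sapiens) for inhibition, read by MTT assay, with a stated time of 96 h; on this read-out higher numbers stand for an effect only at larger amounts of compound and lower numbers for an effect already at smaller amounts. Compound 2 `CC(C)Cn1c(=O)n(C)c(=O)c2nc(CCCCCCO)c(Cc3cccc4ccccc34)nc21` gives 1690 nM in this assay. Compound 3 `CC(C)Cn1c(=O)n(C)c(=O)c2nc(-c3[nH]nnc3CCCO)c(Cc3cccc4ccccc34)nc21` gives 6020 nM in this assay, and it is the least active of the three: the steps of a 160-fold higher number from compound 1 to compound 3 (2.21 log units; beyond the scatter) and a 3.6-fold higher number from compound 2 to compound 3 (0.55 log units; beyond the scatter) both lie beyond the scatter, as does a 46-fold higher number from compound 1 to compound 2 (1.66 log units; beyond the scatter).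

Compound 4 `CC(C)Cn1c(=O)n(C)c(=O)c2nc(-c3c(CCCO)nnn3C)c(Cc3cccc4ccccc34)nc21` differs from compound 3 only by methyl in place of hydrogen on an aromatic nitrogen. Among the measured compounds shown here, no measured step bears directly on this change: every step seen so far swaps the whole side chain, whereas here the side chain is kept and only the triazole ring nitrogen carries the methyl. With nothing to anchor a direction, the expectation is a step of about a 1.0-fold lower number from compound 3 to compound 4 (0.00 log units; within the scatter) in this assay, that is, none clearly beyond the scatter. Compound 4 is therefore estimated at 6000 nM in this assay, with a range from 2000 nM to 18000 nM.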

Compound 4, half-maximal effective concentration: > 10000 nM
Compound 4: a limit, no number; the forecaster's own chance of this, stated with the estimate: 10%; middle value at least 1.6-fold (0.22 log units) from the limit.
By their numbers in this assay, from the lowest: compound 1; then compound 2; then compound 3. At a limit, above all of these: compound 4.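

Compound 4 gives no number in this assay, only a limit: the limit of > 10000 nM in this assay, at which 1 of the 4 values shown sits. Among the compounds shown here, this is the first change that leaves the side chain in place and alters only the triazole ring, and methyl on this aromatic nitrogen brings no measurable recovery of activity: the step reads an at least 1.6-fold higher number from compound 3 to compound 4 (0.22 log units; that floor lies within the scatter), so its floor alone does not establish a real loss. The gaps to the two non-triazole side chains are clearer, at an at least 5.9-fold higher number from compound 2 to compound 4 (0.77 log units; beyond the scatter) and an at least 270-fold higher number from compound 1 to compound 4 (2.43 log units; beyond the scatter), so this methyl does not bring the triazole series closer to the activity of the (4-hydroxybutyl)sulfanyl chain.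

On these data alone, the true size of the methyl step stays open behind the limit. Also open, as far as these compounds go, is whether an ethyl group or a chain ending in an amine on this nitrogen would behave the same way.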